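Adding a Tosyl Group to a Phenol at the Assay Limit

The source may hold more compounds than are shown below. What is called first, only, known or untested is meant among the compounds shown, and "the series" means these compounds.

Compound 1 `C=C1C[C@]23C[C@@]1(O)CC[C@H]2c1ccc(OS(=O)(=O)c2ccc(C)cc2)c(C)c1[C@@H]3Cn1cc(-c2ccc(C)cc2)nn1` shares its core with the rest of the set. In a functional assay on SW480 cells (Homo sapiens) for cytotoxicity, read by MTT assay, with a stated time of 4 days (a higher number here means a weaker inhibitor, a lower number a stronger inhibitor), compound 1 reaches only the limit of the assay, > 20000 nM, not a number. Among the measured compounds shown here, compound 2 `C=C1C[C@]23C[C@@]1(O)CC[C@H]2c1ccc(O)c(C)c1[C@@H]3Cn1cc(-c2ccc(C(F)(F)F)cc2)nn1` differs from compound 1 in more than one place, so no single step links them. In this assay compound 2 likewise stops at the limit, > 20000 nM. Compound 3 `C=C1C[C@]23C[C@@]1(O)CC[C@H]2c1ccc(O)c(C)c1[C@@H]3Cn1cc(-c2ccccc2)nn1` differs from compound 2 by hydrogen in place of trifluoromethyl on an aromatic carbon. In this assay compound 3 also gives only the limit, > 20000 nM. The step that the two limits leave unreadable from compound 2 to compound 3 therefore cannot be read. All that is known of compound 2 is that it sits at the limit, as do the other two values shown (the limit of > 20000 nM in this assay, at which 3 of the 3 values shown sit). Compound 4 `C=C1C[C@]23C[C@@]1(O)CC[C@H]2c1ccc(OS(=O)(=O)c2ccc(C)cc2)c(C)c1[C@@H]3Cn1cc(-c2ccc(C(F)(F)F)cc2)nn1` arises from compound 2 through ((4-methylphenyl)sulfonyl in place of hydrogen on an oxygen on an aromatic ring). For the measured compounds named here, no measured step traces this change; the only hint is that compound 1, which also carries the ((4-methylphenyl)sulfonyl)oxy group, sits at the same limit. Hence no step beyond the scatter is expected: a step that the limit leaves unreadable from compound 2 to compound 4. Compound 4 is expected to give about 25000 nM, within a range from 10000 nM to 60000 nM, and quite possibly again only as a limit.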

Compound 4, half-maximal inhibitory concentration: > 20000 nM
Compound 4 gave a limit, no number (the forecaster's own chance of this, stated with the estimate: 85%); the middle value lies beyond the limit too.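

Neither step, from compound 2 to compound 4 or from compound 1 to compound 4, can be read, as all these compounds give a limit and not a number: the limit of > 20000 nM in this assay, at which 4 of the 4 values shown sit.

The compounds shown leave open whether either change, hydroxy to ((4-methylphenyl)sulfonyl)oxy or methyl to trifluoromethyl, alters the result in this assay.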